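Compound 3 to Compound 4: Pyrrolidin-1-yl Becomes Piperidin-1-yl

The source may hold more compounds than are shown below. What is called first, only, known or untested is meant among the compounds shown, and "the series" means these compounds.

Three related compounds have been tested in a functional assay on MDA-MB-231 cells (Homo sapiens) for inhibition, with a stated time of 72 h; on this read-out lower numbers stand for stronger inhibition and higher numbers for weaker inhibition. Compound 1 `COc1ccc(NC(=O)Nc2nc(Sc3c[nH]c4ccccc34)cc(N3CCCCC3)n2)cc1` gives 7260 nM, compound 2 `Cc1ccc(C)c(NC(=O)Nc2nc(Sc3c[nH]c4ccccc34)cc(N3CCCCC3)n2)c1` gives 5940 nM and compound 3 `O=C(Nc1ccc(Cl)cc1)Nc1nc(Sc2c[nH]c3ccccc23)cc(N2CCCC2)n1` gives 5850 nM. Compound 3 therefore stands level with the other two, its number lying within the usual scatter of both.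

The next compound, compound 4 `O=C(Nc1ccc(Cl)cc1)Nc1nc(Sc2c[nH]c3ccccc23)cc(N2CCCCC2)n1`, keeps everything in compound 3 except one group: piperidin-1-yl in place of pyrrolidin-1-yl on an aromatic carbon, (piperidin-1-yl in place of pyrrolidin-1-yl on an aromatic carbon).

Among the compounds with values here, the only measured step between two compounds that differ in one place is a 1.2-fold lower number from compound 1 to compound 2 (0.09 log units; within the scatter). It lies within the scatter, but it concerns the group on an amide-type nitrogen, not the ring changed here, so it bears on this change only indirectly. Within the data shown here, no measured pair isolates this swap. Compound 2 already carries piperidin-1-yl, though with a different group on the amide-type nitrogen, and its 5940 nM sits within the scatter of compound 3 at 5850 nM. No step beyond the scatter is therefore expected in this assay. The expected step is a 1.0-fold lower number from compound 3 to compound 4 (0.02 log units; within the scatter), which would stay within the scatter. For compound 4 the estimated value is 5600 nM, with an expected range from 2900 nM to 10500 nM.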

Compound 4, half-maximal inhibitory concentration: 10100 nM
Compound 4: the middle estimate sits 1.8-fold (0.26 log units) below what was measured, and the stated range covers the measured number.
By their numbers in this assay, from the lowest: compounds 3, 2, 1 and 4 (each within the scatter of the next).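

Within the data shown here, compounds 3 and 4 are the first pair that isolates this position. With everything else held constant, replacing the five-membered pyrrolidin-1-yl ring on the aromatic carbon with the six-membered piperidin-1-yl ring gives a step in this assay that stays within the scatter (a 1.7-fold higher number from compound 3 to compound 4 (0.24 log units; within the scatter)), so this assay does not separate the two rings in the presence of the 4-chlorophenyl group. Compound 4 also allows the group on the amide-type nitrogen to be compared with piperidin-1-yl in place, and neither 4-chlorophenyl in place of 2,5-dimethylphenyl (a 1.7-fold higher number from compound 2 to compound 4 (0.23 log units; within the scatter)) nor chloro in place of methoxy on the aromatic ring (a 1.4-fold higher number from compound 1 to compound 4 (0.14 log units; within the scatter)) gives a step beyond the scatter. No other measurement bears on these results, so they offer no explanation for the small differences seen.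

Going by these compounds, whether a ring carrying a second hetero atom, such as morpholin-4-yl or piperazin-1-yl, or an open-chain amine such as dimethylamino would behave the same way at this position remains open. The compounds shown also leave open whether the ring swap would give the same result with 4-methoxyphenyl or 2,5-dimethylphenyl on the amide-type nitrogen.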